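The compounds below may be only part of what the source reports. "The series", "measured", "known", "first", "only" and "open" are said of these compounds alone.

Of the compounds shown here, three built on one shared core have been tested in a functional assay on MCF7 cells (Homo sapiens) for inhibition, read by sulforhodamine B assay, with a stated time of 48 h, tested at 1 uM; on this read-out lower numbers stand for a stronger effect and higher numbers for a weaker effect at the one concentration tested. Compound 1 `O=C(Nc1cccc(-n2cc(-c3ccncc3)c(-c3cc(O)cc(Cl)c3)n2)c1)Nc1ccc(Cl)c(C(F)(F)F)c1` gives 91% in this assay, and compound 2 `O=C(Nc1cccc(-n2cc(-c3ccncc3)c(-c3cc(O)cc(Cl)c3)n2)c1)Nc1ccc(Cl)c(Cl)c1` gives 91%. For the measured compounds named here, the one step measured between them, no change at the digits printed from compound 1 to compound 2 (within the scatter), shows that exchanging one substituent for another on the urea-bearing ring left the read-out where it was. Compound 3 `COc1cc(Cl)cc(-c2nn(-c3cccc(NC(=O)Nc4cc(C(F)(F)F)cc(C(F)(F)F)c4)c3)cc2-c2ccncc2)c1` stands apart from both: in this assay compound 3 gives 21%, the lowest of the three numbers, and its distance to compound 1 and to compound 2 lies well beyond the scatter.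

Compound 4 `COc1cc(Cl)cc(-c2nn(-c3cccc(NC(=O)Nc4cccc(C(F)(F)F)c4)c3)cc2-c2ccncc2)c1` differs from compound 3 in a single place: hydrogen in place of trifluoromethyl on an aromatic carbon. Going by the values given here, no measured step matches this change. Among the compounds with values here, the only step at hand swapped one group for another of similar size and stayed within the scatter, so it bears on the present question only loosely; removing a group entirely is a different kind of change, and the data give no direct precedent. Since compound 3 already sits at the strong end, the more likely direction for compound 4 is a weaker effect, of uncertain size. Compound 4 is therefore expected to give 50% in this assay, with a range from 20% to 85%, an expected step of a number 29 percentage points higher from compound 3 to compound 4 (beyond the scatter).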

Compound 4, a percentage reported as activity, at one concentration (the size of the read-out at that concentration, not a potency): 62%
Compound 4: the middle estimate sits 12 percentage points below what was measured, within the range that was stated.
By their numbers in this assay, from the lowest: compound 3; then compound 4; then compounds 1 and 2 (each within the scatter of the next).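

In this assay, for the compounds shown here, replacing trifluoromethyl with hydrogen on this aromatic carbon, meta to a large group and meta to a trifluoromethyl group, gives a number 41 percentage points higher from compound 3 to compound 4 (beyond the scatter), the first step to lie beyond the scatter. Going by these compounds alone, the only earlier step, no change at the digits printed from compound 1 to compound 2 (within the scatter), exchanged one substituent for another at a different place on a different background, so it said nothing about this position; the new step shows that the read-out at this position depends on whether the trifluoromethyl group is present, and that losing it markedly weakens the effect at the one concentration tested. Nothing at hand explains why this change moves the read-out so far.

The compounds shown leave open whether the effect needs trifluoromethyl itself at this position or whether another group, such as chloro, methyl, an amine or a carboxylic acid, would hold the read-out near that of compound 3. They also leave open whether the same exchange would have a step of similar size on a core carrying the hydroxyl group of compound 1 rather than the methoxy group of compound 3.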